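A few compounds are considered here, and "the series" means these few. Any claim that something is new, unique, unknown or untested is made for them only; others in the source may bear on it.

Three compounds built on a shared core were examined in an assay on membranes from HeLa cells for displacement of a labelled ligand from adenosine receptor A3 (Homo sapiens), read by scintillation counting, with a stated time of 180 min, tested at 1 uM; a lower number here means less inhibition, a higher number more inhibition at the concentration tested (going by the name of the read-out). Compound 1 `CCCC(=O)C1=C(C)NC(=O)NC1c1ccsc1` gives 1%, compound 2 `CC1=C(C(=O)NC(C)C)C(c2ccsc2)NC(=O)N1` gives 1%, and compound 3 `CCSC(=O)C1=C(C)NC(=O)NC1c1ccsc1` gives 2%. Within the data shown here, compound 3 holds the highest of the three numbers, yet it is separated from neither of the others by more than the scatter: the steps read a number 1 percentage points higher from compound 1 to compound 3 (within the scatter) and a number 1 percentage points higher from compound 2 to compound 3 (within the scatter), and between the first two compounds no change at the digits printed from compound 1 to compound 2 (within the scatter). Every exchange of the group on the carbonyl carbon so far, whether propyl, isopropylamino or ethylsulfanyl, has left the read-out flat.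

Compound 4 `CC1=C(C(=O)SC(C)C)C(c2ccsc2)NC(=O)N1` is now to be measured in the same assay. It differs from compound 3 by methyl in place of hydrogen on a saturated chain carbon bound to a saturated chain carbon and a sulfur. Among the measured compounds shown here, the steps that bear on this are those that altered the same carbonyl-bound group, and none of them rose above the scatter, so the change from compound 3 to compound 4 is expected to be small as well, no change at the digits printed from compound 3 to compound 4 (within the scatter). Compound 4 is therefore estimated at 2%, with a range from -5% to 10%.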

Compound 4, a percentage reported as inhibition, at one concentration (the size of the read-out at that concentration, not a potency): 1%
Beside the measured number, compound 4's estimate is 1 percentage points above it, within the range that was stated.
By their numbers in this assay, from the lowest: compounds 1, 2, 4 and 3 (each within the scatter of the next).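

In this assay, ethylsulfanyl gives way to isopropylsulfanyl on the carbonyl carbon with a number 1 percentage points lower from compound 3 to compound 4 (within the scatter), so adding methyl on the saturated chain carbon bound to the sulfur leaves the read-out flat, as the exchanges of the whole group did. Isopropylsulfanyl in place of isopropylamino gives no change at the digits printed from compound 2 to compound 4 (within the scatter), and isopropylsulfanyl in place of propyl gives no change at the digits printed from compound 1 to compound 4 (within the scatter), so all four groups on this carbonyl carbon now read alike. No measurement is at hand that would account for these readings.

The compounds shown leave open whether another group on the carbonyl carbon, such as an ethoxy group, a benzyl group or a longer chain, would move this read-out. They also leave open whether any change elsewhere on the shared core would do so.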